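Replacing 4-nitrophenyl with tert-butyl on a carbonyl carbon

This account rests on a few compounds, and the source may have more. Where it says the series, first, only, none or still open, it means among the compounds named here.

In a functional assay on BHK-21 cells (Mesocricetus auratus) for cytotoxicity, read by MTT assay (a higher number here means that more compound is tolerated, a lower number that less compound is tolerated), compound 1 (`O=C(c1ccccc1)N1N=C(c2cccs2)CC1c1ccc(Cl)cc1`) reads > 300000 nM, which is a limit and not a number. For the measured compounds named here, compound 2 (`CN1CCN(c2cc(-c3ccc(C(C)(C)C)cc3)c3ccccc3n2)CC1`), which has a different core, gives 110000 nM, the only true number so far. Compound 3 (`O=C(c1ccc([N+](=O)[O-])cc1)N1N=C(c2cccs2)CC1c1ccc(Cl)cc1`) reads > 300000 nM, again a limit and not a number.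

Compound 4 (`CC(C)(C)C(=O)N1N=C(c2cccs2)CC1c1ccc(Cl)cc1`) differs from compound 3 at one place: tert-butyl in place of 4-nitrophenyl on a carbonyl carbon. Going by the values given here, the one measured step that bears on this change is a step that the two limits leave unreadable from compound 1 to compound 3, so it offers no size to carry over. Compound 1 and compound 3 both stand at the limit of > 300000 nM in this assay, at which 2 of the 3 values shown sit. No step beyond the scatter is therefore expected in this assay, and neither direction is favoured. The estimated change is a number no higher from compound 3 to compound 4 (the limit leaves the size open). It is also expected to be more likely than not that the assay again reports only a limit. For compound 4 the estimated value is 300000 nM, with an expected range from 130000 nM to 600000 nM.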

Compound 4, half-maximal cytotoxic concentration: 90000 nM
For compound 4 the middle estimate is 3.3-fold (0.52 log units) above the measured one; the whole stated range lies above it.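

In this assay, for the compounds shown here, the group on this carbonyl carbon now proves able to change the read-out: the aromatic groups of compound 1 and compound 3 gave no step that could be read, whereas tert-butyl gives an at least 3.3-fold lower number from compound 3 to compound 4 (0.52 log units; beyond the scatter) and an at least 3.3-fold lower number from compound 1 to compound 4 (0.52 log units; beyond the scatter). Going by these compounds alone, compound 4 is also the first compound on this shared core to give a number and not a limit. Both steps are minimum sizes only, and compound 1 and compound 3 remain limits: the limit of > 300000 nM in this assay, at which 2 of the 4 values shown sit.

With a single non-aromatic group shown, the compounds cannot separate the loss of the aromatic ring from other differences between tert-butyl and the groups it replaces. On these data alone, how a methyl group, a longer chain or a carboxylic acid in the same place would read remains open.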